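Swapping the side chain of compound 1

This account rests on a few compounds, and the source may have more. Where it says the series, first, only, none or still open, it means among the compounds named here.

Compound 1 (`CCN(CC)CC(=O)NC1CC2(N3CCN(C)CC3)CC(c3ccccc3)C1C(c1ccccc1)C2`) stands at 26400 nM in an ADME assay on L6 cells (Rattus norvegicus) for cytotoxicity, read by fluorescence, with a stated time of 72 h (a higher number here means a weaker inhibitor, a lower number a stronger inhibitor), and compound 2 (`CN1CCN(C23CCN(CCCN4CCCC4)C(C(c4ccccc4)C2)C(c2ccccc2)C3)CC1`) at 43500 nM within the usual scatter of it, so neither stands apart. For the measured compounds named here, compound 3 (`CN1CCN(C23CC(NCCCN4CCCC4)C(C(c4ccccc4)C2)C(c2ccccc2)C3)CC1`) has no measurement yet. The change from compound 1 (3-(pyrrolidin-1-yl)propyl in place of ((diethylamino)methyl)carbonyl on an amine nitrogen) puts 3-(pyrrolidin-1-yl)propyl in place of ((diethylamino)methyl)carbonyl on an amine nitrogen. With only these two measured compounds as guides, no shift beyond the scatter is expected in this assay for this change. The estimated move is a 1.2-fold lower number from compound 1 to compound 3 (0.08 log units; within the scatter) and stays within the scatter. The estimate for compound 3 is 22000 nM as an expected middle, with 9000 nM to 50000 nM as its expected range.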

Compound 3, half-maximal inhibitory concentration: 22600 nM
The estimate for compound 3 lay 1.0-fold (0.01 log units) below the measured number; the range from low to high includes it.
By their numbers in this assay, from the lowest: compounds 3, 1 and 2 (each within the scatter of the next).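

On an amine nitrogen, 3-(pyrrolidin-1-yl)propyl in place of ((diethylamino)methyl)carbonyl gives a 1.2-fold lower number from compound 1 to compound 3 (0.07 log units; within the scatter) in this assay and so shows no shift beyond the scatter. This single pair shows that, in this assay, the carbonyl can leave this position and a pyrrolidine ring can enter without the number moving measurably. No measurement shown here offers an explanation for this.

Still open, going by these compounds, is whether a shorter chain, a carboxylic acid or a phenyl ring on this nitrogen would move the number beyond the scatter.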